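The source may report more compounds than this note shows. Statements on the series, on what has been measured and on what is new or still open speak of the compounds shown alone.

Measured in an ADME assay on HEK293 cells (Homo sapiens) for cytotoxicity, read by CellTiter-Glo, with a stated time of 72 h; a higher number here means that more compound is needed for the effect, a lower number that less compound is needed:

- Compound 1 `CC1=C2CC(C)(C)/C=C/C/C(C)=C\C3=C[C@H](C)C[C@]3(O2)C1=O`: 26000 nM
- Compound 2 `CC1=C2CC(C)(C)/C=C/[C@H](OC(=S)n3ccnc3)/C(C)=C\C3=C[C@H](C)C[C@]3(O2)C1=O`: 26000 nM
- Compound 3 `COc1ccc(/C2=C\C(=O)/C(C)=C\C3=C[C@H](C)C[C@@]34OC(=C(C)C4=O)CC2(C)C)cc1`: 26000 nM

All three compounds give the same number, so compound 3 stands level with the other two and has neither the highest nor the lowest value. Compound 4 `CC1=C2CC(C)(C)/C(c3ccccc3)=C/C(=O)/C(C)=C\C3=C[C@H](C)C[C@]3(O2)C1=O` differs from compound 3 in one place: hydrogen in place of methoxy on an aromatic carbon. In words, hydrogen stands in place of methoxy on an aromatic carbon, which turns 4-methoxyphenyl into phenyl.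

For the measured compounds named here, no measured step involves this group, so the evidence is indirect. Going by the values given here, the only step available is no change at the digits printed from compound 1 to compound 2 (within the scatter), and it concerns a different group, on a saturated ring carbon. Even so, it shows this read-out staying put despite a substantial structural change. Compound 3, with its 4-methoxyphenyl group, also sits at 26000 nM. No step beyond the scatter is therefore expected, and the expected step is no change at the digits printed from compound 3 to compound 4 (within the scatter). Compound 4 is estimated at 26000 nM, with an expected range of 13000 nM to 45000 nM.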

Compound 4, half-maximal effective concentration: 26000 nM
Compound 4: the middle estimate sits on the measured number at the digits printed, within the range that was stated.
By their numbers in this assay, from the lowest: compounds 1, 2, 3 and 4 (each within the scatter of the next).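

In this assay, taking the methoxy off the 4-methoxyphenyl group to leave phenyl produces no change that can be told from the scatter (no change at the digits printed from compound 3 to compound 4 (within the scatter)). For the compounds shown here, this is the first measured step on an aromatic carbon: the earlier step concerned a different group on a saturated ring carbon. So, for this pair, the methoxy on the six-membered aromatic ring makes no visible difference to the read-out, and hydrogen serves equally well there. Nothing measured here explains this result, which stands as a plain observation.

The compounds shown leave open whether a different group at this place, such as an amine, a carboxylic acid or a longer chain, would shift the number away from the level shared by all four compounds.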